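Ring size of the cyclic amide on the shared core

The source may report more compounds than this note shows. Statements on the series, on what has been measured and on what is new or still open speak of the compounds shown alone.

Measured in an assay on HEK293 cells for inhibition of transient receptor potential cation channel subfamily M member 8 (Homo sapiens), read by FLIPR, with stated times of 5 min and 3 min; on this read-out higher numbers stand for weaker inhibition and lower numbers for stronger inhibition: compound 1 `O=C(c1sc(-c2cccc(F)c2)nc1O)N1CCOC1` gives 5500 nM; compound 2 `O=C(c1sc(-c2cccc(F)c2)nc1O)N1CCCCO1` gives 167 nM; compound 3 `CCON(C)C(=O)c1sc(-c2cccc(F)c2)nc1O` gives 1680 nM.

Compound 3 stands second highest of the three numbers: the step of a 3.3-fold lower number from compound 1 to compound 3 (0.52 log units; beyond the scatter) lies beyond the scatter, as does the step of a 10-fold higher number from compound 2 to compound 3 (1.00 log units; beyond the scatter). Compound 4 `O=C(c1sc(-c2cccc(F)c2)nc1O)N1CCCCCO1` differs from compound 3 by a group of 7 heavy atoms (5 carbon, 1 nitrogen, 1 oxygen; one seven-membered non-aromatic ring with 2 hetero atoms) in place of a group of 5 heavy atoms (3 carbon, 1 nitrogen, 1 oxygen; no ring), on a carbonyl carbon. For the measured compounds named here, two measured steps bear on this: the step of a 33-fold lower number from compound 1 to compound 2 (1.52 log units; beyond the scatter), a ring enlarged by one atom, and the step of a 10-fold higher number from compound 2 to compound 3 (1.00 log units; beyond the scatter), ring opened to a chain. Going by the values given here, a closed ring larger than that of compound 2 has no measured precedent, so a lower number than compound 3 is expected, though perhaps not as low as compound 2. Compound 4 is estimated at 350 nM, range 90 nM to 1500 nM, an expected step of a 4.8-fold lower number from compound 3 to compound 4 (0.68 log units; beyond the scatter).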

Compound 4, half-maximal inhibitory concentration: 32 nM
The estimate for compound 4 lay 11-fold (1.04 log units) above the measured number, outside the stated range (below it).
By their numbers in this assay, from the lowest: compound 4; then compound 2; then compound 3; then compound 1.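

In this assay, the number at this carbonyl carbon keeps falling as the ring grows past six members, with a 5.2-fold lower number from compound 2 to compound 4 (0.72 log units; beyond the scatter), and across the ring compounds the change reaches a 170-fold lower number from compound 1 to compound 4 (2.24 log units; beyond the scatter). The seven-membered ring also far outdoes the open ethoxy(methyl)amino chain, with a 53-fold lower number from compound 3 to compound 4 (1.72 log units; beyond the scatter). Nothing measured here accounts for these steps.

Going by these compounds, whether an eight-membered ring lowers the number further remains open. So does whether azepane, the seven-membered ring with only its nitrogen as hetero atom, keeps the gain.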